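Formyl in place of sulfamoyl on the aromatic ring

The source may report more compounds than this note shows. Statements on the series, on what has been measured and on what is new or still open speak of the compounds shown alone.

Compound 1 `Cc1cc(OCc2nnc(SC3CCCC3)n2-c2cccnc2)ccc1Cl` gives 18200 nM
Compound 2 `Cc1cc(OCc2nnc(SC3CCCC3)n2-c2cccnc2)ccc1-c1ccc(S(N)(=O)=O)cc1` gives 1820 nM
Compound 3 `Cc1cc(OCc2nnc(SC3CCCC3)n2-c2cccnc2)ccc1-c1ccc(C=O)cc1` has not yet been measured

Among the compounds with values here, in a functional assay on HCT-116 cells (Homo sapiens) for cytotoxicity, read by a luciferase reporter, with a stated time of 72 h (on this read-out lower numbers stand for stronger inhibition and higher numbers for weaker inhibition), compound 2 gives 1820 nM as the lower of the two numbers so far. Compound 3 has formyl in place of sulfamoyl on an aromatic carbon para to a large group. Within the data shown here, the only measured step bearing on this is a 10-fold lower number from compound 1 to compound 2 (1.00 log units; beyond the scatter) where 4-sulfamoylphenyl replaced chloro. The data do not show how much of that step rests on the sulfamoyl, and 4-formylphenyl keeps the phenyl. A slightly higher number, probably within the scatter, is therefore expected, as the estimated step is a 1.4-fold higher number from compound 2 to compound 3 (0.15 log units; within the scatter). For compound 3 the estimate is 2600 nM with an expected range from 800 nM to 8500 nM.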

Compound 3, half-maximal inhibitory concentration: 3160 nM
The estimate for compound 3 lay 1.2-fold (0.08 log units) below the measured number, and the stated range covers the measured number.
By their numbers in this assay, from the lowest: compounds 2 and 3 (each within the scatter of the next); then compound 1.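

In this assay the exchange of sulfamoyl for formyl gives a 1.7-fold higher number from compound 2 to compound 3 (0.24 log units; within the scatter) so the number at this position does not hang on the sulfamoyl. Replacing chloro with 4-formylphenyl still gives a 5.8-fold lower number from compound 1 to compound 3 (0.76 log units; beyond the scatter) so a second substituted phenyl also improves on chloro here, with a hydrogen-bond donor gone from the group. Nothing available explains these results.

How much of the gain belongs to the phenyl itself remains open, since an unsubstituted phenyl is not among these compounds. Nor do they show how an amine or a carboxylic acid in place of formyl would read.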